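The source may hold more compounds than are shown below. What is called first, only, known or untested is meant among the compounds shown, and "the series" means these compounds.

Measured so far in an ADME assay on HepG2 cells (Homo sapiens) for cytotoxicity, read by luminescence, CellTiter-Glo and ATP content, with a stated time of 72 h; on this read-out lower numbers stand for an effect already at smaller amounts and higher numbers for an effect only at larger amounts of compound:

compound 1, `COc1ccccc1Oc1ccc2c(NCCCNCc3ccco3)ccnc2c1` — 6500 nM
compound 2, `Fc1ccc(Cc2ccc3c(NCCCNCc4ccco4)ccnc3c2)c(Cl)c1` — 5730 nM
compound 3, `c1coc(CNCCCNc2ccnc3cc(-c4cccc5ccccc45)ccc23)c1` — 5600 nM

The three measured compounds share one core and differ only in the group on one aromatic carbon. Compound 3 holds the lowest number of the three, yet both neighbours sit within the scatter: a 1.0-fold lower number from compound 2 to compound 3 (0.01 log units; within the scatter) and a 1.2-fold lower number from compound 1 to compound 3 (0.06 log units; within the scatter). The remaining pair, a 1.1-fold lower number from compound 1 to compound 2 (0.05 log units; within the scatter), is likewise within the scatter. Across these three substituents the read-out in this assay has not moved beyond repeat variation.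

Compound 4, `CCC(CC)c1ccc2c(NCCCNCc3ccco3)ccnc2c1`, is not yet measured. It differs from compound 3 as follows: pentan-3-yl in place of naphthalen-1-yl on an aromatic carbon. The change sits at the same aromatic carbon as the three measured steps, so those steps are the only ones that bear on it; all were within the scatter. No step beyond the scatter is therefore expected in this assay, in either direction: the expected step is a 1.1-fold higher number from compound 3 to compound 4 (0.03 log units; within the scatter). The wider range below reflects that pentan-3-yl, with no ring, lies outside the measured set.

Compound 4 is estimated at 6000 nM, with a range from 2500 nM to 14000 nM.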

Compound 4, half-maximal effective concentration: 6760 nM
The estimate for compound 4 lay 1.1-fold (0.05 log units) below the measured number, within the range that was stated.
By their numbers in this assay, from the lowest: compounds 3, 2, 1 and 4 (each within the scatter of the next).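

In this assay, pentan-3-yl, with 5 heavy atoms and no ring, replaces each of the three earlier groups on this aromatic carbon without leaving the scatter (a 1.2-fold higher number from compound 3 to compound 4 (0.08 log units; within the scatter); a 1.2-fold higher number from compound 2 to compound 4 (0.07 log units; within the scatter); a 1.0-fold higher number from compound 1 to compound 4 (0.02 log units; within the scatter)). The earlier compounds shown here all carried an aromatic ring in this group, so they could not show that the read-out holds without one; across the four compounds, neither a ring nor the drop from 10 heavy atoms in naphthalen-1-yl to 5 in pentan-3-yl separates the numbers. Nothing measured here accounts for this flatness.

Still open, as far as these compounds go, is whether an amine or a carboxylic acid on this carbon would produce a step beyond the scatter. The compounds also leave open how a change elsewhere, such as a longer chain in the shared side chain, would read in this assay.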